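The source may report more compounds than this note shows. Statements on the series, on what has been measured and on what is new or still open speak of the compounds shown alone.

The read-out throughout is an ADME assay on L1210/0 cells (Mus musculus) for cytotoxicity, with a stated time of 48 h; on this read-out higher numbers stand for weaker inhibition and lower numbers for stronger inhibition. Compound 1 `O=C1O/C(=C\Cn2cc(I)c(=O)[nH]c2=O)C(OCc2ccccc2)=C1OCc1ccccc1` gives 7500 nM in this assay. Compound 2 `O=c1[nH]c(=O)n([C@H]2C[C@H](O)[C@@H](CO)O2)cc1[N+](=O)[O-]` gives 130 nM in this assay. For compound 3 `O=c1ccn(CC2CCC(CO)C2)c(=O)[nH]1` the result in this assay is not a number but a limit of the assay, > 200000 nM; this is the same limit recorded as the limit of > 200000 nM in this assay, at which 1 of the 3 values shown sits. Among the two real numbers, compound 2 stands lowest, and compound 1 sits above it by a gap well beyond the scatter of repeated measurements, so compound 2 is the stronger inhibitor of the pair.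

Compound 4 `C#COc1cn([C@H]2C[C@H](O)[C@@H](CO)O2)c(=O)[nH]c1=O` has not been measured. It differs from compound 2 in a single place: ethynyloxy in place of nitro on an aromatic carbon. Among the compounds with values here, no two measured compounds differ by this change alone, so no measured step tells its size directly, and the expectation rests on compound 2 alone. The step is expected to be a moderate rise in the number, meaning weaker inhibition, so that the expected change in this assay is a 15-fold higher number from compound 2 to compound 4 (1.19 log units; beyond the scatter). Compound 4 is therefore expected to give about 2000 nM in this assay, with a likely range between 200 nM and 20000 nM.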

Compound 4, half-maximal inhibitory concentration: > 200000 nM
Compound 4 gave a limit, no number; the forecaster's own chance of this, stated with the estimate: 10%; middle value at least 100-fold (2.00 log units) away from the limit.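

Swapping nitro for ethynyloxy on this aromatic carbon gives, in this assay, an at least 1500-fold higher number from compound 2 to compound 4 (3.18 log units; beyond the scatter). Within the data shown here, no earlier pair differed in one place only, so this step is the first direct view of this position: with the rest of the core unchanged, a single group of the same heavy-atom count turns a clear inhibitor into a compound with no measurable value. Compound 4 gives a limit and not a number, so the true size of the step stays unknown: the limit of > 200000 nM in this assay, at which 2 of the 4 values shown sit.

On this core, the compounds shown carry only nitro and ethynyloxy at this carbon, so they cannot tell whether nitro itself is needed for the inhibition or whether ethynyloxy alone is what harms it. A plain hydrogen, an amine, a methoxy group or a longer chain at the same carbon would help to separate these two readings and show how much of the range between the two compounds can be reached at this position.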